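A few compounds are considered here, and "the series" means these few. Any claim that something is new, unique, unknown or untested is made for them only; others in the source may bear on it.

Compounds measured in a functional assay on ECV-304 cells (Homo sapiens) for cytotoxicity; on this read-out lower numbers stand for stronger inhibition and higher numbers for weaker inhibition:

- Compound 1 `Cc1cccc(/C=C2\SC(=S)N(NS(=O)(=O)c3ccccc3)C2=O)c1`: > 50000 nM
- Compound 2 `O=S(=O)(NN1C(=S)S/C(=C\c2ccc(Cl)c(Cl)c2)C1O)c1ccc(Cl)cc1`: > 50000 nM
- Compound 3 `O=C1/C(=C/c2ccc(Cl)c(Cl)c2)SC(=S)N1NS(=O)(=O)c1cccs1`: > 50000 nM

In this assay compound 1 stands at > 50000 nM, and this is a limit of the assay, not a number. Compound 2 and compound 3 are likewise reported only as limits. One observation therefore sums up the set: the limit of > 50000 nM in this assay, at which 3 of the 3 values shown sit. For the measured compounds named here, no two measured compounds differ in one place alone, so the data give no measured size for a single change.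

The next compound to be tested is compound 4 `N#Cc1ccc(/C=C2\SC(=S)N(NS(=O)(=O)c3ccccc3)C2=O)cc1`. It carries 4-cyanophenyl in place of 3-methylphenyl on a double-bonded chain carbon bound to a double-bonded ring carbon, and otherwise keeps the core of compound 1: 4-cyanophenyl in place of 3-methylphenyl on a double-bonded chain carbon bound to a double-bonded ring carbon.

The expectation for this change rests on compound 1, whose reading is the limit > 50000 nM. The estimated step of a number no higher from compound 1 to compound 4 (the limit leaves the size open) is expected to stay within the usual scatter, with no direction favoured, and the assay may well report only a limit again. For compound 4 the expected value is 50000 nM, with an estimated range from 25000 nM to 100000 nM.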

Compound 4, half-maximal inhibitory concentration: > 50000 nM
Compound 4 gave a limit, no number; the forecaster's own chance of this, stated with the estimate: 75%; the middle value lies on the limit itself.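

In this assay compound 4 gives > 50000 nM, which is a limit and not a number. Compound 1 is also reported only as a limit, so no step can be read between compound 1 and compound 4. The set reduces to one observation: the limit of > 50000 nM in this assay, at which 4 of the 4 values shown sit.

The compounds shown leave open what size any single change has in this assay.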